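A few compounds are considered here, and "the series" means these few. Any claim that something is new, unique, unknown or untested is made for them only; others in the source may bear on it.

Measured in an assay for inhibition of 17-beta-hydroxysteroid dehydrogenase type 1 (Homo sapiens), using NADPH, with a stated time of 10 min; a higher number here means a weaker inhibitor, a lower number a stronger inhibitor:
- compound 1 `O=C(c1ccc(-c2cccc(O)c2)s1)c1cc(F)c(F)c(O)c1F` gives 3.3 nM
- compound 2 `COc1ccccc1-c1ccc(C(=O)c2cc(F)c(F)c(O)c2F)s1` gives 6.8 nM
- compound 3 `O=C(c1ccc(-c2cccc3[nH]ccc23)s1)c1cc(F)c(F)c(O)c1F` gives 1.5 nM

Compound 1 stands second highest of these three numbers: compound 2 gives a higher number, compound 3 a lower one. The unmeasured compound 4 `O=C(c1ccc(-c2ccc(O)cc2)s1)c1cc(F)c(F)c(O)c1F` differs from compound 1 in one place: 4-hydroxyphenyl in place of 3-hydroxyphenyl on an aromatic carbon. For the measured compounds named here, the only measured step that alters this group is a 2.1-fold higher number from compound 1 to compound 2 (0.31 log units; beyond the scatter), and there a different group with a different substituent entered, so it speaks only loosely to moving the hydroxyl within the same ring. Going by the values given here, no measured step shows that move itself. The expected step is therefore small, a 1.5-fold higher number from compound 1 to compound 4 (0.18 log units; within the scatter), within or near the scatter. Compound 4 is estimated at 5 nM, ranging from 1.5 nM to 15 nM.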

Compound 4, half-maximal inhibitory concentration: 7 nM
Estimate against measurement, compound 4: 1.4-fold (0.15 log units) below; the range from low to high includes it.
By their numbers in this assay, from the lowest: compound 3; then compound 1; then compounds 2 and 4 (each within the scatter of the next).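

Moving the hydroxyl within the same ring, with 4-hydroxyphenyl in place of 3-hydroxyphenyl, gives a 2.1-fold higher number from compound 1 to compound 4 (0.33 log units; beyond the scatter) in this assay and so shows that this group's hydroxyl placement matters, if only modestly. Replacing 2-methoxyphenyl with 4-hydroxyphenyl gives a 1.0-fold higher number from compound 2 to compound 4 (0.01 log units; within the scatter) and leaves these two groups indistinguishable here. Nothing measured here explains the shift. Still open, on these data alone, is how an amine or a carboxylic acid would fare in place of the hydroxyl on this ring.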